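The compounds below may be only part of what the source reports. "The series", "measured", "known", "first", "only" and "open" are said of these compounds alone.

Of the compounds shown here, three built on a shared core have been tested in an ADME assay on MT4 cells (Homo sapiens) for cytotoxicity, read by MTT assay; on this read-out higher numbers stand for lower toxicity in this test and lower numbers for higher toxicity in this test. Compound 1 `O=C1c2ccccc2C(=O)N1CCOC(=S)N(C(=O)c1ccccc1[N+](=O)[O-])c1ccc(Cl)cc1` gives 21000 nM, the lowest number of the three. Compound 2 `Cc1ccc(N(C(=O)c2ccccc2[N+](=O)[O-])C(=S)OCCN2C(=O)c3ccccc3C2=O)cc1` gives 100000 nM, and compound 3 `Cc1ccc(C(=O)N(C(=S)OCCN2C(=O)c3ccccc3C2=O)c2ccc(C)cc2)cc1` gives 83000 nM.

Compound 4 `O=C1c2ccccc2C(=O)N1CCOC(=S)N(C(=O)c1ccc(F)cc1F)c1ccc(Cl)cc1` has not yet been measured. It differs from compound 1 in one place, with 2,4-difluorophenyl in place of 2-nitrophenyl on a carbonyl carbon.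

For the measured compounds named here, the most relevant evidence is the one measured step that also replaces 2-nitrophenyl on that carbonyl carbon. Swapping in 4-methylphenyl gives a 1.2-fold lower number from compound 2 to compound 3 (0.08 log units; within the scatter), which lies within the scatter. The other measured step, a 4.8-fold higher number from compound 1 to compound 2 (0.68 log units; beyond the scatter), is larger and beyond the scatter, but it belongs to methyl in place of chloro on an aromatic carbon, and compound 4 keeps the chloro of compound 1. Going by the values given here, this evidence has limits: the carbonyl swap was seen only once, in a methyl-bearing compound, and no compound carrying 2,4-difluorophenyl has been measured.

No step beyond the scatter is therefore expected, and the estimated step is a 1.1-fold higher number from compound 1 to compound 4 (0.06 log units; within the scatter). For compound 4 the estimated value is 24000 nM, with an expected range from 9000 nM to 60000 nM.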

Compound 4, half-maximal cytotoxic concentration: 52000 nM
Beside the measured number, compound 4's estimate is 2.2-fold (0.34 log units) below it; measured number inside the range.
By their numbers in this assay, from the lowest: compound 1; then compounds 4, 3 and 2 (each within the scatter of the next).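

In this assay, replacing the 2-nitrophenyl group on this carbonyl carbon can change the number: 2,4-difluorophenyl gives a 2.5-fold higher number from compound 1 to compound 4 (0.39 log units; beyond the scatter), whereas the only earlier replacement at this place, 4-methylphenyl in a compound with methyl in place of chloro, gave a 1.2-fold lower number from compound 2 to compound 3 (0.08 log units; within the scatter). The earlier compounds shown here therefore did not show that this position could move the result beyond the scatter, and here the move is towards lower toxicity in this test, with the chloro of compound 1 kept. No measurement is available to explain why this replacement shifts the number.

As far as these compounds go, whether the size of this step depends on the chloro remains open: 2,4-difluorophenyl appears here only in chloro-bearing compound 4, while the 4-methylphenyl replacement appears only in methyl-bearing compound 3, so the two replacements cannot be compared directly. From the compounds shown here alone, it is also open how the number would respond to quite different groups on the same carbonyl carbon, such as a cyclohexyl ring or a phenyl ring carrying an amine or a carboxylic acid.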